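Cytotoxicity notes on moving the chloro group

The source may report more compounds than this note shows. Statements on the series, on what has been measured and on what is new or still open speak of the compounds shown alone.

Compounds measured so far in an ADME assay on Huh-7 cells (Homo sapiens) for cytotoxicity; a lower number here means that less compound is tolerated, a higher number that more compound is tolerated:
- compound 1, `CN1CCN(CCNCc2cn(-c3ccc(F)cc3F)nc2Cc2ccccc2)CC1`: > 20000 nM
- compound 2, `CN1CCN(CCNCc2cn(-c3ccc(F)cc3F)nc2-c2ccccc2)CC1`: > 20000 nM
- compound 3, `CN1CCN(CCNCc2cn(-c3ccc(F)cc3F)nc2-c2cccc(Cl)c2)CC1`: 15000 nM

The value of compound 1 is a limit of this assay, not a number. The value of compound 2 is likewise a limit. Both sit at the limit of > 20000 nM in this assay, at which 2 of the 3 values shown sit. Going by the values given here, compound 3 therefore gives the only number in the set.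

The step of an at least 1.3-fold lower number from compound 2 to compound 3 (0.12 log units; that floor lies within the scatter) and the step of an at least 1.3-fold lower number from compound 1 to compound 3 (0.12 log units; that floor lies within the scatter) have floors that lie within the scatter; the step that the two limits leave unreadable from compound 1 to compound 2 cannot be read from the two limits.

Compound 4, `CN1CCN(CCNCc2cn(-c3ccc(F)cc3F)nc2-c2ccc(Cl)cc2)CC1`, carries the change (4-chlorophenyl in place of 3-chlorophenyl on an aromatic carbon). Among the compounds with values here, no measured step exchanges one chlorophenyl for another, and the only step introducing chloro, from compound 2 to compound 3, has a floor within the scatter. The step that is therefore expected is no change at the digits printed from compound 3 to compound 4 (within the scatter). Compound 4 is estimated at 15000 nM, with a range from 7000 nM to 30000 nM.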

Compound 4, half-maximal cytotoxic concentration: 19000 nM
Estimate against measurement, compound 4: 1.3-fold (0.10 log units) below, and the stated range covers the measured number.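

In this assay, the chloro group moves around the phenyl ring with a 1.3-fold higher number from compound 3 to compound 4 (0.10 log units; within the scatter), so 4-chlorophenyl and 3-chlorophenyl are not told apart at this position. Against the chloro-free compounds only floors exist, an at least 1.0-fold lower number from compound 2 to compound 4 (0.02 log units; that floor lies within the scatter) and an at least 1.0-fold lower number from compound 1 to compound 4 (0.02 log units; that floor lies within the scatter), and neither shows an effect of adding chloro. Those floors rest on one assay limit: the limit of > 20000 nM in this assay, at which 2 of the 4 values shown sit.

From the compounds shown here alone, the step between the two limits cannot be read, and whether chloro changes the tolerated concentration at all remains open. Also open, going by these compounds, is whether an amine or a carboxylic acid on this phenyl ring would give a step beyond the scatter.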